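Swapping the ether-linked pyridine for a triazolylmethylamine

The source may report more compounds than this note shows. Statements on the series, on what has been measured and on what is new or still open speak of the compounds shown alone.

Compound 1 `Cc1cc(OCc2ccccn2)n2nc(C)c(-c3ccccc3)c2n1` is the reference point here. For the measured compounds named here, in a physicochemical assay for solubility, read by HPLC, using the shake flask method, measured as kinetic solubility, with a stated time of 2 h, at pH 7.4 (on this read-out higher numbers stand for higher solubility and lower numbers for lower solubility), compound 1 gives 25600 nM, the only full number in this set. Compound 2 `Cc1cc(NCc2ccccn2)n2ncc(-c3cc(F)c(F)c(F)c3)c2n1` is also known, but in this assay compound 2 reaches only a limit, < 5000 nM, so its result is not a number (the limit of < 5000 nM in this assay, at which 1 of the 2 values shown sits). Compound 2 differs from compound 1 in more than one place, so the two values show no more than that one compound has a number and the other a limit. Compound 3 `Cc1cc(NCc2ncnn2C)n2nc(C)c(-c3ccccc3)c2n1` has not been measured; it carries ((1-methyl-1H-1,2,4-triazol-5-yl)methyl)amino in place of (pyridin-2-yl)methoxy on an aromatic carbon. Going by the values given here, with no comparable step available, any expectation rests on compound 1 alone, and the step from compound 1 to compound 3 is expected to be modest in either direction, a 1.2-fold higher number from compound 1 to compound 3 (0.07 log units; within the scatter). Compound 3 is therefore estimated at 30000 nM, with a range from 8000 nM to 100000 nM.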

Compound 3, solubility: 185000 nM
Beside the measured number, compound 3's estimate is 6.2-fold (0.79 log units) below it; measured number outside the range, above it.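

For the compounds shown here, the earlier compounds offered no comparison differing in one place, and this is the first: in this assay, ((1-methyl-1H-1,2,4-triazol-5-yl)methyl)amino in place of (pyridin-2-yl)methoxy gives a 7.2-fold higher number from compound 1 to compound 3 (0.86 log units; beyond the scatter). With the rest of the molecule unchanged, the read-out clearly responds to what stands on this aromatic carbon, next to the ring nitrogen. Nothing measured here gives a reason for the size of this step.

The change replaces the aromatic ring and the linking atom together, so the compounds shown leave open which of the two accounts for the step. Also open, from the compounds shown here alone, is how a simple amine such as morpholine, with no aromatic ring, or a longer chain between the linking atom and the triazole would read on this carbon.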